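Swapping an Oxygen Linker for Sulfur on a Shared Core

The compounds below may be only part of what the source reports. "The series", "measured", "known", "first", "only" and "open" are said of these compounds alone.

Measured compounds:
compound 1 `Nc1cc(N)c2nc(-c3ccccc3)c(NCc3ccc(F)cc3)nc2c1`: < 100000 nM
compound 2 `COc1ccc(Sc2nc3cc(N)cc(N)c3nc2-c2ccccc2)cc1`: < 100000 nM
compound 3 `Nc1cc(N)c2nc(-c3ccccc3)c(Oc3ccc(F)cc3)nc2c1`: < 100000 nM

Of the compounds shown here, three on a shared core have been tested in a functional assay on HCT-116 cells (Homo sapiens) for inhibition, read by sulforhodamine B assay, with a stated time of 48 h; a higher number here means that more compound is tolerated, a lower number that less compound is tolerated. For compound 1 the result is only a limit of the assay, < 100000 nM. For compound 2 the result is likewise a limit, < 100000 nM. Compound 3 also gives only a limit in this assay, < 100000 nM. Because of the limit of < 100000 nM in this assay, at which 3 of the 3 values shown sit, none of the three steps between these compounds can be sized: a step that the two limits leave unreadable from compound 1 to compound 2, a step that the two limits leave unreadable from compound 1 to compound 3 and a step that the two limits leave unreadable from compound 2 to compound 3 all remain unreadable.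

Compound 4 `Nc1cc(N)c2nc(-c3ccccc3)c(Sc3ccc(F)cc3)nc2c1` is the next compound. It differs from compound 3 in one place: (4-fluorophenyl)sulfanyl in place of 4-fluorophenoxy on an aromatic carbon. Within the data shown here, no measured step speaks directly to this exchange, and the three unreadable steps give no size to lean on. What is known is that compound 3 sits at the limit in this assay, so compound 4 is expected near that same region. The step from compound 3 to compound 4 is estimated to be a step that the limit leaves unreadable from compound 3 to compound 4, a guess rather than a prediction. For compound 4 the expected value in this assay is 30000 nM, with a range from 3000 nM to 100000 nM.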

Compound 4, concentration lethal to 50% of the cells: 55000 nM
Estimate against measurement, compound 4: 1.8-fold (0.26 log units) below; the range from low to high includes it.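

Compound 4 gives a real number, 55000 nM.

Among these compounds, no step from compound 1, compound 2 or compound 3 to compound 4 can be read, because those three compounds give only a limit: the limit of < 100000 nM in this assay, at which 3 of the 4 values shown sit.

Which of 4-fluorophenoxy and (4-fluorophenyl)sulfanyl on the shared core gives the lower value stays open.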